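Chloro in Place of Methyl Among Growth Inhibitors

A few compounds are considered here, and "the series" means these few. Any claim that something is new, unique, unknown or untested is made for them only; others in the source may bear on it.

In a functional assay on NPC-TW01 cells (Homo sapiens) for inhibition, read by MTT assay, with a stated time of 72 h (on this read-out higher numbers stand for weaker inhibition of growth and lower numbers for stronger inhibition of growth), compound 1 (`CN(C)/C=N/c1c(C=O)c(-c2ccc(Cl)cc2)nn1-c1cccc(Cl)c1`) gives 7400 nM and compound 2 (`Cc1ccc(-c2nn(-c3ccc(Br)cc3)c(/N=C/N(C)C)c2C=O)cc1`) gives 6000 nM as two numbers within the scatter of each other. Compound 3 (`CN(C)/C=N/c1c(C=O)c(-c2ccc(Cl)cc2)nn1-c1ccc(Br)cc1`) arises from compound 2 with chloro in place of methyl on an aromatic carbon. Within the data shown here, no measured step shows this change. Compound 1 also carries 4-chlorophenyl and gives 7400 nM in this assay despite differing elsewhere, so no step beyond the scatter is expected. The estimated change is a 1.1-fold higher number from compound 2 to compound 3 (0.03 log units; within the scatter) in either direction. Compound 3 is expected at 6500 nM within an estimated range of 3000 nM to 13000 nM in this read-out.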

Compound 3, concentration for 50% growth inhibition: > 100000 nM
Compound 3: no number, only a limit; the forecaster's own chance of this, stated with the estimate: 5%; middle value at least 15-fold (1.18 log units) from the limit.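

Chloro in place of methyl on an aromatic carbon is far from a neutral exchange at this position: in this assay it gives an at least 16-fold higher number from compound 2 to compound 3 (1.22 log units; beyond the scatter). Compound 3 has a limit of the assay, not a number: the limit of > 100000 nM in this assay, at which 1 of the 3 values shown sits. Compound 1 also carries 4-chlorophenyl, yet 4-bromophenyl in place of 3-chlorophenyl on the aromatic nitrogen gives an at least 13-fold higher number from compound 1 to compound 3 (1.13 log units; beyond the scatter), so among these compounds the loss appears only where 4-chlorophenyl and 4-bromophenyl occur together.

The compounds shown leave open why this pairing fails. They also leave open how a methoxy group or an amine at this position would fare alongside 4-bromophenyl.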